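The source may hold more compounds than are shown below. What is called first, only, known or untested is meant among the compounds shown, and "the series" means these compounds.

Compound 1 `Nc1nc(C2CCCO2)nc2sc(Cc3ccccc3)cc12` carries an oxolan-2-yl group on the shared core. In a functional assay on CHO-K1 cells for antagonist activity at adenosine receptor A1 (Homo sapiens), read by a beta-galactosidase reporter and cAMP accumulation, with stated times of 15 min and 6 h (on this read-out lower numbers stand for stronger inhibition and higher numbers for weaker inhibition), compound 1 gives 2950 nM, the higher of the two values recorded so far. Compound 2 `Cc1csc(-c2nc(N)c3cc(Cc4ccccc4F)sc3n2)n1`, which bears an aromatic substituent on that core together with a fluorinated benzyl group, gives in this assay a value of 28.6 nM; the gap between these two values lies well beyond the scatter. Compound 3 `Nc1nc(-c2ncccn2)nc2sc(Cc3ccccc3)cc12` has not yet been measured. It differs from compound 1 in one place: pyrimidin-2-yl in place of oxolan-2-yl on an aromatic carbon. Compound 2 shows 28.6 nM with an aromatic group on the core, while compound 1 shows 2950 nM with a non-aromatic one, although compound 2 differs in a second place too. On that basis a downward step a 20-fold lower number from compound 1 to compound 3 (1.29 log units; beyond the scatter) beyond the scatter is expected. In this assay compound 3 is estimated at 150 nM, within a range from 30 nM to 800 nM.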

Compound 3, inhibition constant: 618 nM
Estimate against measurement, compound 3: 4.1-fold (0.61 log units) below; the measured number falls inside the stated range.
By their numbers in this assay, from the lowest: compound 2; then compound 3; then compound 1.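

In this assay the exchange of oxolan-2-yl for pyrimidin-2-yl, on the aromatic carbon between two ring nitrogen atoms, gives a 4.8-fold lower number from compound 1 to compound 3 (0.68 log units; beyond the scatter) with nothing else in the structure altered. The group at this position is thus enough on its own to move the number beyond the scatter, which compound 2 could not show, as it differs from compound 1 in a second place too. What lies behind the step is not addressed by any data given here.

The compounds shown leave open how phenyl, a six-membered aromatic ring without ring nitrogen atoms, or an open-chain amine would compare at this position. They also leave open whether the step would hold with the fluorinated benzyl group of compound 2 in place of the plain benzyl group.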